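The source may hold more compounds than are shown below. What is called first, only, known or untested is meant among the compounds shown, and "the series" means these compounds.

Values in an ADME assay on the whole organism (Mus musculus, strain CD-1) for pharmacokinetics, at a dose of 10 mg/kg by the oral route; on this read-out higher numbers stand for higher oral bioavailability and lower numbers for lower oral bioavailability:
- compound 1 `CCOc1cc([C@](O)(CCN(C)C)[C@@H](c2cc3cc(Br)ccc3nc2OC)c2cccc(OC)c2F)cc(OC)n1`: 46%
- compound 2 `CCOc1cc([C@](O)(CCN(C)C)[C@H](c2cccc(C)c2)c2cc3cc(Br)ccc3nc2OC)cc(OC)n1`: 65%
- compound 3 `CCOc1cc([C@](O)(CCN(C)C)[C@@H](c2cc3cc(Br)ccc3nc2OC)c2ccnc(OC)c2OC)cc(OC)n1`: 70%

Compound 1 stands lowest of the three. Compound 4 `COc1cc([C@](O)(CCN(C)C)[C@@H](c2cc3cc(Br)ccc3nc2OC)c2cccc(OC)c2F)cc(OC(C)C)n1` turns its ethoxy into isopropoxy: methyl in place of hydrogen on a saturated chain carbon bound to an oxygen on an aromatic ring and a saturated chain carbon.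

Going by the values given here, no measured step touches this group. All three replace the aryl group elsewhere: a number 19 percentage points higher from compound 1 to compound 2 (beyond the scatter), a number 24 percentage points higher from compound 1 to compound 3 (beyond the scatter) and a number 5 percentage points higher from compound 2 to compound 3 (within the scatter). They show only how far this assay can move in this series. With a single added methyl, the expected result is no change at the digits printed from compound 1 to compound 4 (within the scatter), a step not beyond the scatter. The estimate for compound 4 is 46%, with an expected range of 29% to 63%.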

Compound 4, oral bioavailability: 43%
The estimate for compound 4 lay 3 percentage points above the measured number, within the range that was stated.
By their numbers in this assay, from the lowest: compounds 4 and 1 (each within the scatter of the next); then compounds 2 and 3 (each within the scatter of the next).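

In this assay, ethoxy to isopropoxy gives a number 3 percentage points lower from compound 1 to compound 4 (within the scatter), so this position tolerates one added methyl on the saturated chain carbon bound to the oxygen on the aromatic ring. Among the compounds shown, only aryl replacements give steps beyond the scatter. Nothing available bears on the reason for this result.

Going by these compounds, whether a longer chain, a tert-butoxy group or a chain carrying an amine would hold the number here remains open. So does whether the same methyl gives a similar step on compound 2 or compound 3.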